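A few compounds are considered here, and "the series" means these few. Any claim that something is new, unique, unknown or untested is made for them only; others in the source may bear on it.

Two amides of a shared core have been measured in a functional assay on PC-3 cells (Homo sapiens) for inhibition, read by sulforhodamine B assay, with a stated time of 72 h; a lower number here means a stronger inhibitor, a higher number a weaker inhibitor. Compound 1 `Nc1sc(-c2ccc(Cl)cc2)c(-c2ccc(Cl)cc2)c1C(=O)Nc1ccccc1`, with anilino on the carbonyl carbon, gives > 50000 nM, which is a limit of the assay and not a number. Going by the values given here, compound 2 `Nc1sc(-c2ccc(Cl)cc2)c(-c2ccc(Cl)cc2)c1C(=O)N1CCCC1` gives 6220 nM, the only true number so far. Among the compounds with values here, the single measured step is an at least 8.0-fold lower number from compound 1 to compound 2 (0.90 log units; beyond the scatter), with pyrrolidin-1-yl in place of anilino on a carbonyl carbon, and its full size is unknown since one end is a limit.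

Compound 3 `COc1ccc(CNC(=O)c2c(N)sc(-c3ccc(Cl)cc3)c2-c2ccc(Cl)cc2)cc1` is changed at that same place: (4-methoxybenzyl)amino in place of pyrrolidin-1-yl on a carbonyl carbon. In words, (4-methoxybenzyl)amino stands in place of pyrrolidin-1-yl. Within the data shown here, no measured step covers this exact exchange, so the guide is indirect. The step of an at least 8.0-fold lower number from compound 1 to compound 2 (0.90 log units; beyond the scatter) shows that the group on the carbonyl carbon can move the number in this assay, and losing pyrrolidin-1-yl is therefore expected to give a modest move to a higher number, with some chance of none beyond the scatter. The expected change is a 1.9-fold higher number from compound 2 to compound 3 (0.29 log units; within the scatter). Compound 3 is estimated at 12000 nM, with an expected range from 3000 nM to 45000 nM.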

Compound 3, half-maximal inhibitory concentration: 29500 nM
The estimate for compound 3 lay 2.5-fold (0.39 log units) below the measured number; low and high end bracket the measured number.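

In this assay, the step of a 4.7-fold higher number from compound 2 to compound 3 (0.68 log units; beyond the scatter), with (4-methoxybenzyl)amino in place of pyrrolidin-1-yl on the carbonyl carbon, lies beyond the scatter, so this position now has a second exchange that separates from pyrrolidin-1-yl. Among the three amides shown, compound 2, which has no amide hydrogen, gives a lower number than either compound 1 or compound 3, which both carry one, and no compound shown goes against this. The step of an at least 1.6-fold lower number from compound 1 to compound 3 (0.22 log units; that floor lies within the scatter) has a floor within the scatter, and its full size stays unknown because compound 1 gives a limit of the assay and not a number: the limit of > 50000 nM in this assay, at which 1 of the 3 values shown sits.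

The three compounds do not separate the loss of the amide hydrogen from the change of group as a whole, and a dimethylamino or piperidin-1-yl group on the carbonyl carbon would bear on whether the lower number of compound 2 is particular to pyrrolidin-1-yl. The part played by the methoxy group in compound 3 also remains open, as a plain benzylamino group does not appear among the compounds shown.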